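Swapping the heteroaryl ring: from compound 2 to compound 4

This account rests on a few compounds, and the source may have more. Where it says the series, first, only, none or still open, it means among the compounds named here.

Measured compounds:
compound 1, `COC1NN=C(C[S+]([O-])C(c2ccccc2)c2ccccc2)S1`, 108000 nM
compound 2, `CC(C)c1nnsc1C[S+]([O-])C(c1ccccc1)c1ccccc1`, 69100 nM
compound 3, `[O-][S+](Cc1cccs1)C(c1ccc(F)cc1)c1ccc(F)cc1`, 4000 nM

All three numbers come from an assay on HEK293 cells for inhibition of sodium-dependent dopamine transporter (Homo sapiens), read by scintillation counting, with stated times of 5 min and 1 min; on this read-out higher numbers stand for weaker inhibition and lower numbers for stronger inhibition. Compound 2 stands second highest of the three: compound 1 sits a step away that is within the scatter, while compound 3 lies far lower, beyond it. Compound 4, `[O-][S+](Cc1cc(Br)cs1)C(c1ccccc1)c1ccccc1`, has not yet been measured. It is made from compound 2 by one change, (4-bromothiophen-2-yl in place of 4-isopropyl-1,2,3-thiadiazol-5-yl on a saturated chain carbon bound to a sulfur).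

Within the data shown here, only one measured step bears on such a ring swap: a 1.6-fold lower number from compound 1 to compound 2 (0.19 log units; within the scatter), a change of one five-membered ring for another that left the number essentially where it was. Compound 3 also carries a five-membered ring with one hetero atom on the same chain carbon, but it differs from compound 4 in more than one place, so its much lower value can only hint, not measure, what the ring swap does. Taken together, compound 4 is expected to give a lower number than compound 2, a 5.8-fold lower number from compound 2 to compound 4 (0.76 log units; beyond the scatter), with wide uncertainty. The estimate for compound 4 in this assay is 12000 nM, between 3000 nM and 45000 nM.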

Compound 4, half-maximal inhibitory concentration: 13700 nM
The estimate for compound 4 lay 1.1-fold (0.06 log units) below the measured number; measured number inside the range.
By their numbers in this assay, from the lowest: compound 3; then compound 4; then compounds 2 and 1 (each within the scatter of the next).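

In this assay the group on a saturated chain carbon bound to a sulfur clearly matters: 4-bromothiophen-2-yl in place of 4-isopropyl-1,2,3-thiadiazol-5-yl gives a 5.0-fold lower number from compound 2 to compound 4 (0.70 log units; beyond the scatter) and so moves the number beyond the scatter, which the earlier swap of a 1.6-fold lower number from compound 1 to compound 2 (0.19 log units; within the scatter) did not do. Set against the non-aromatic ring of compound 1, the same group gives a 7.9-fold lower number from compound 1 to compound 4 (0.90 log units; beyond the scatter) and so compound 1 and compound 2 both stand at higher numbers than compound 4. Nothing measured here explains these steps.

Still open, as far as these compounds go, is whether the bromine or the thiophene ring itself carries the step, which only the plain thiophen-2-yl group on the same core could settle. Also open, from the compounds shown here alone, is how a chlorine, a methyl or an amine would read in place of that bromine.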